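Adding a Ring Methyl to a Dimethylsulfamoyl Alkyne Acid

The compounds below may be only part of what the source reports. "The series", "measured", "known", "first", "only" and "open" are said of these compounds alone.

Compound 1, `COCCN(C)S(=O)(=O)c1ccc(C)c(C#Cc2cc(Cl)ccc2OCC(=O)O)c1`, gives 4.1 nM in an assay on CHO cells for displacement of a labelled ligand from prostaglandin D2 receptor 2 (Homo sapiens), read by scintillation counting; on this read-out higher numbers stand for weaker inhibition and lower numbers for stronger inhibition.
Compound 2, `Cc1ccc(S(=O)(=O)NC(C)C)cc1C#Cc1cc(Cl)ccc1OCC(=O)O`, gives 3.4 nM in this assay.
Compound 3, `CN(C)S(=O)(=O)c1cccc(C#Cc2cc(Cl)ccc2OCC(=O)O)c1`, gives 14 nM in this assay.

Compound 3 stands highest of the three numbers in this assay, that is, it is the weakest binder shown: compound 1 lies a step beyond the scatter below it, and compound 2 lies further still. The new compound, compound 4, `Cc1ccc(S(=O)(=O)N(C)C)cc1C#Cc1cc(Cl)ccc1OCC(=O)O`, differs from compound 3 by one change: methyl in place of hydrogen on an aromatic carbon. This methyl sits on the same aromatic carbon that already carries a methyl in compound 1 and compound 2.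

Among the compounds with values here, only one measured step bears on the question. From compound 1 to compound 2 the group on the sulfonyl sulfur changed, and the result was a 1.2-fold lower number from compound 1 to compound 2 (0.08 log units; within the scatter). Swapping the amine part of the sulfonamide therefore does little on its own, which leaves the ring methyl as the most likely source of the gap between compound 3 and the two methyl-bearing compounds. Compound 4 is accordingly expected to move toward the values of compound 1 and compound 2, a step of a 2.8-fold lower number from compound 3 to compound 4 (0.45 log units; beyond the scatter), and is estimated at 5 nM, within 2.5 nM to 10 nM.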

Compound 4, inhibition constant: 5 nM
Estimate against measurement, compound 4: no gap at the digits printed; measured number inside the range.
By their numbers in this assay, from the lowest: compounds 2, 1 and 4 (each within the scatter of the next); then compound 3.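

Compound 3 and compound 4 differ only by this methyl, so the effect of the position can now be read directly rather than inferred: a methyl on this aromatic carbon, ortho to a large group and para to a dimethylsulfamoyl group, gives a 2.8-fold lower number from compound 3 to compound 4 (0.45 log units; beyond the scatter) in this assay, a modest gain from a single added carbon. Once the methyl is present, the three sulfonamide groups shown give closely matched results, with a 1.5-fold higher number from compound 2 to compound 4 (0.17 log units; within the scatter) and a 1.2-fold higher number from compound 1 to compound 4 (0.09 log units; within the scatter) both staying inside the usual scatter, so among these compounds the group on the sulfonyl sulfur is not what separates them. The data shown give the size of the step from the methyl. No measurement offered here goes further than that size.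

The compounds shown leave open whether an ethyl group, a chlorine atom or a methoxy group on the same carbon would do as well as the methyl or better. Going by these compounds, compound 1 and compound 2 also have no partner carrying hydrogen on that carbon, so it remains unknown whether the methyl gives a similar step alongside their sulfonamide groups.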